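The source may hold more compounds than are shown below. What is called first, only, known or untested is meant among the compounds shown, and "the series" means these compounds.

Compound 3 `CCN(c1ccc(C#N)c(Cl)c1)c1cc(-c2ccco2)ccc1C` sits at the weak end of this series: in a functional assay on PC-3 cells (Homo sapiens) for antiproliferative activity, read by CCK-8 assay, with a stated time of 6 days (on this read-out lower numbers stand for stronger inhibition and higher numbers for weaker inhibition), compound 3 gives > 30000 nM, which is a limit of the assay rather than a number. That places it at the limit of > 30000 nM in this assay, at which 1 of the 3 values shown sits. For comparison, compound 2 `CCN(c1ccc(C#N)c(Cl)c1)c1cc(-c2cnc3ccccc3c2)ccc1C` carries a quinolin-3-yl where compound 3 carries a furan-2-yl; in this assay compound 2 gives 3570 nM. Compound 1 `N#Cc1ccc(N2CCc3cc(-c4cnc5ccccc5c4)ccc32)cc1C(F)(F)F` has no result in this assay, its value being "not determined" (no result reported).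

The step from compound 3 to compound 4 `CCN(c1ccc(C#N)c(Cl)c1)c1cc(-c2cccnc2)ccc1C` is pyridin-3-yl in place of furan-2-yl on an aromatic carbon. Among the compounds with values here, no measured pair traces this change directly. With a six-membered aromatic ring entering in place of the five-membered one, and compound 2 with its own six-membered aromatic ring giving 3570 nM, compound 4 is expected to inhibit more strongly than compound 3 does, although by a smaller amount than compound 2 shows. The step from compound 3 to compound 4 is estimated as an at least 2.0-fold lower number from compound 3 to compound 4 (0.30 log units; that floor lies within the scatter). Compound 4 is therefore expected to give about 15000 nM in this assay, within a range of 4000 nM to 30000 nM.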

Compound 4, half-maximal inhibitory concentration: 11000 nM
Estimate against measurement, compound 4: 1.4-fold (0.13 log units) above; low and high end bracket the measured number.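

Putting pyridin-3-yl in place of furan-2-yl on this aromatic carbon gives an at least 2.7-fold lower number from compound 3 to compound 4 (0.43 log units; beyond the scatter) in this assay, so a single six-membered aromatic ring at this place is enough to yield a measurable number, which earlier was shown only for the quinolin-3-yl of compound 2. On these data alone, the true size of this step stays unknown because compound 3 stands at a limit of the assay: the limit of > 30000 nM in this assay, at which 1 of the 4 values shown sits. Compound 4 at 11000 nM still gives a higher number than compound 2 at 3570 nM, so the single pyridine ring does not reach what the quinolin-3-yl shows.

The compounds shown do not tell whether the ring nitrogen matters here, since neither a plain phenyl nor a pyridin-4-yl stands at this place. Nor do they say how a pyridine ring carrying an amine or a methoxy group would read.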